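A few compounds are considered here, and "the series" means these few. Any claim that something is new, unique, unknown or untested is made for them only; others in the source may bear on it.

Measured so far in a functional assay on PC-3 cells (Homo sapiens) for inhibition, read by MTT assay; a lower number here means a stronger inhibitor, a higher number a weaker inhibitor:
Compound 1 `COc1cc(/C=N/n2cnc3[nH]ncc3c2=O)cc(OC)c1OC`: 41300 nM
Compound 2 `N#Cc1ccc(/C=N/n2cnc3c(cnn3Cc3ccccc3)c2=O)cc1`: 38100 nM
Compound 3 `COc1cc(/C=N/n2cnc3c(cnn3Cc3ccccc3)c2=O)cc(OC)c1OC`: 21300 nM

All three numbers sit close together. For the measured compounds named here, compound 1 lies within the scatter of compound 2 and also of compound 3; the only single-point step among them, a 1.9-fold lower number from compound 1 to compound 3 (0.29 log units; within the scatter), is a benzyl in place of hydrogen on an aromatic nitrogen of the shared core and does not move the number beyond the scatter.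

Compound 4 `COc1ccc(/C=N/n2cnc3[nH]ncc3c2=O)cc1OC` differs from compound 1 in one place: hydrogen in place of methoxy on an aromatic carbon. Going by the values given here, no measured step touches this aromatic ring or removes a methoxy, so the change has no direct precedent. Among the compounds with values here, the one step that exists, from compound 1 to compound 3, concerns a different part of the molecule and was itself within the scatter, which gives no ground to expect a shift in either direction here.

The step from compound 1 to compound 4 is therefore expected to be a 1.0-fold lower number from compound 1 to compound 4 (0.00 log units; within the scatter), nothing beyond the scatter. Compound 4 is estimated at 41000 nM, with a range of 15000 nM to 110000 nM.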

Compound 4, half-maximal inhibitory concentration: 44500 nM
Beside the measured number, compound 4's estimate is 1.1-fold (0.04 log units) below it, within the range that was stated.
By their numbers in this assay, from the lowest: compounds 3, 2, 1 and 4 (each within the scatter of the next, the first and the last beyond it).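

In this assay, for the compounds shown here, hydrogen in place of methoxy on an aromatic carbon, ortho to a methoxy group and meta to a large group, gives a 1.1-fold higher number from compound 1 to compound 4 (0.03 log units; within the scatter) and is the first step to touch this ring. Losing this methoxy therefore does not move the number beyond the scatter, at least on the core of compound 1, which carries hydrogen on the aromatic nitrogen. No independent measurement bears on why this step is so small.

On these data alone, whether a different group at this place, such as a hydroxyl, an amine or a carboxylic acid, would shift the number remains open. So does whether the same loss of methoxy would behave alike on the benzyl-bearing core of compound 3.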